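Ring size change in the amine tail of compound 3

The compounds below may be only part of what the source reports. "The series", "measured", "known", "first", "only" and "open" are said of these compounds alone.

Compound 1 `COc1cc2c(Oc3ccc(NC(=O)c4cc(-c5ccccc5)nc5ccccc45)cc3F)ccnc2cc1OCCCN1CCCCC1` gives 530 nM in a functional assay on HT-29 cells (Homo sapiens) for cytotoxicity, read by MTT assay, with a stated time of 72 h; a higher number here means a weaker inhibitor, a lower number a stronger inhibitor.
Compound 2 `COc1cc2c(Oc3ccc(NC(=O)c4cc(-c5ccc(F)cc5)nc5ccccc45)cc3F)ccnc2cc1OCCCN1CCCCC1` gives 130 nM in this assay.
Compound 3 `COc1cc2c(Oc3ccc(NC(=O)c4cc(-c5ccc(Cl)c(Cl)c5)nc5ccccc45)cc3F)ccnc2cc1OCCCN1CCCCC1` gives 1210 nM in this assay.

Among the three measured compounds, compound 3 stands at the highest number in this assay: the step of a 2.3-fold higher number from compound 1 to compound 3 (0.36 log units; beyond the scatter) and the step of a 9.3-fold higher number from compound 2 to compound 3 (0.97 log units; beyond the scatter) both lie beyond the scatter, so compound 3 is the weakest inhibitor of the three. The remaining measured step, a 4.1-fold lower number from compound 1 to compound 2 (0.61 log units; beyond the scatter), is also beyond the scatter.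

Compound 4 `COc1cc2c(Oc3ccc(NC(=O)c4cc(-c5ccc(Cl)c(Cl)c5)nc5ccccc45)cc3F)ccnc2cc1OCCCN1CCCC1` differs from compound 3 in one place: pyrrolidin-1-yl in place of piperidin-1-yl on a saturated chain carbon, three bonds along the chain from an oxygen on an aromatic ring. None of the three measured steps touches this part of the molecule; each of them alters the aryl group attached to the shared core, while the amine at the end of the propyl chain is the same in compounds 1, 2 and 3. Among the measured compounds shown here, there is thus no measured step that bears on the change from compound 3 to compound 4, and the expectation rests on the number for compound 3 alone. A step no larger than the usual scatter is expected, with no clear direction, so that a 1.0-fold lower number from compound 3 to compound 4 (0.00 log units; within the scatter) is the anticipated outcome. Compound 4 is therefore estimated at 1200 nM, with a range from 450 nM to 3200 nM.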

Compound 4, half-maximal inhibitory concentration: 1960 nM
Beside the measured number, compound 4's estimate is 1.6-fold (0.21 log units) below it; the range from low to high includes it.
By their numbers in this assay, from the lowest: compound 2; then compound 1; then compounds 3 and 4 (each within the scatter of the next).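

In this assay, among the compounds shown here, the amine at the end of the propyl chain is varied here for the first time, and the step from the six-membered piperidin-1-yl ring to the five-membered pyrrolidin-1-yl ring is a 1.6-fold higher number from compound 3 to compound 4 (0.21 log units; within the scatter), which leaves the two compounds indistinguishable. For the compounds shown here, all the earlier steps altered the aryl group on the shared core and all lay beyond the scatter, whereas this pair shows that, with the 3,4-dichlorophenyl group in place, this change of ring size at the end of the chain does not separate the two compounds in this assay. Nothing available bears on why the pair reads this way or gives a measured property of either amine.

One pair on one aryl group leaves open whether the same exchange would read alike with the 4-fluorophenyl group of compound 2 or the phenyl group of compound 1. It also leaves open how the assay would respond to a different amine at this place, such as a morpholine, a methylpiperazine or a dimethylamine, or to a butyl chain in place of the propyl chain.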